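Positional isomer of the methoxyphenyl cap: compound 4

The compounds below may be only part of what the source reports. "The series", "measured", "known", "first", "only" and "open" are said of these compounds alone.

The shared core is that of compound 2 `COc1ccccc1-n1cc(COc2c(/C=C\C(=O)O)ccc(OC)c2CC=C(C)C)nn1`; compound 1 `COc1ccc(/C=C\C(=O)O)c(OCc2cn(-c3ccc(NC(C)=O)cc3)nn2)c1CC=C(C)C` and compound 3 `COc1ccc(/C=C\C(=O)O)c(OCc2cn(-c3ccc(NC(=O)c4ccccc4)cc3)nn2)c1CC=C(C)C` carry other groups on the aromatic nitrogen of the five-membered ring. In a functional assay on NCI-H322 cells (Homo sapiens) for cytotoxicity, read by MTT assay, with a stated time of 24 h (a lower number here means a stronger inhibitor, a higher number a weaker inhibitor), compound 2 gives 41500 nM, compound 1 gives 45700 nM and compound 3 gives 17200 nM. Compound 2 stands second highest of the three numbers; compound 1 is nearest, compound 3 furthest.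

Two steps are known. The exchange of one aryl group for another, a 1.1-fold lower number from compound 1 to compound 2 (0.04 log units; within the scatter), stays within the scatter. The change on the carbonyl carbon, a 2.7-fold lower number from compound 1 to compound 3 (0.42 log units; beyond the scatter), is modest but beyond it.

Compound 4 `COc1cccc(-n2cc(COc3c(/C=C\C(=O)O)ccc(OC)c3CC=C(C)C)nn2)c1` differs from compound 2 in one place: 3-methoxyphenyl in place of 2-methoxyphenyl on an aromatic nitrogen. Within the data shown here, no measured step moves the methoxy group around the same ring, so nothing bears on it directly. Among the measured compounds shown here, the only aryl-for-aryl step seen, a 1.1-fold lower number from compound 1 to compound 2 (0.04 log units; within the scatter), gave no change beyond the scatter, and the one step beyond the scatter, a 2.7-fold lower number from compound 1 to compound 3 (0.42 log units; beyond the scatter), alters the carbonyl carbon, which compound 4 leaves untouched. The expected step is therefore a 1.0-fold lower number from compound 2 to compound 4 (0.02 log units; within the scatter), nothing beyond the scatter. For compound 4 the expected value in this assay is 40000 nM, with a range from 18000 nM to 90000 nM.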

Compound 4, half-maximal inhibitory concentration: 25200 nM
Compound 4: the middle estimate sits 1.6-fold (0.20 log units) above what was measured; the measured number falls inside the stated range.
By their numbers in this assay, from the lowest: compounds 3, 4, 2 and 1 (each within the scatter of the next, the first and the last beyond it).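

In this assay, among these compounds, the methoxy group is moved around the aryl ring on the aromatic nitrogen for the first time, and a 1.6-fold lower number from compound 2 to compound 4 (0.22 log units; within the scatter) shows that the exchange of 2-methoxyphenyl for 3-methoxyphenyl leaves the number within the scatter. The exchange of 4-acetamidophenyl for 3-methoxyphenyl gives a 1.8-fold lower number from compound 1 to compound 4 (0.26 log units; within the scatter) and also stays within the scatter, so the three aryl groups of compound 1, compound 2 and compound 4 show no separation at this position, while the phenyl-for-methyl change on the carbonyl carbon, a 2.7-fold lower number from compound 1 to compound 3 (0.42 log units; beyond the scatter) in the same assay, remains the only listed step beyond the scatter and the one exception to this flat picture. No measurement is at hand that could explain either the small step or the exception.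

On these data alone, whether an ethoxy group or an amine on the same aryl ring would also stay within the scatter of compound 2 remains open. Also open, as far as these compounds go, is whether a longer chain on the carbonyl carbon of compound 1, such as propyl, would give a step like that to compound 3 or one within the scatter.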